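Adding a (phenoxymethyl)carbonyl group to compound 1

The compounds below may be only part of what the source reports. "The series", "measured", "known", "first", "only" and "open" are said of these compounds alone.

Compound 1 `C=C1CC[C@@H]2[C@](C)(CO)[C@H](O)CC[C@@]2(C)[C@@H]1CCc1ccoc1`: 79500 nM
Compound 2 `C=C1CC[C@@H]2[C@](C)(COC(=O)CC)[C@H](OC(=O)CC)CC[C@@]2(C)[C@@H]1CCc1ccoc1`: > 100000 nM (a limit)
Compound 3 `C=C1CC[C@@H]2[C@](C)(COC(=O)C(Cl)Cl)[C@H](OC(=O)C(Cl)Cl)CC[C@@]2(C)[C@@H]1CCc1ccoc1`: 22900 nM

In a functional assay on MCF7 cells (Homo sapiens) for cytotoxicity, read by MTT assay, with a stated time of 48 h (a higher number here means a weaker inhibitor, a lower number a stronger inhibitor), compound 1 gives 79500 nM, the higher of the two actual numbers. The nearest value comes from compound 3 at 22900 nM, lower by a margin beyond the scatter. For compound 2 the assay reports only a limit: > 100000 nM.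

Compound 4 `C=C1CC[C@@H]2[C@](C)(COC(=O)COc3ccccc3)[C@H](O)CC[C@@]2(C)[C@@H]1CCc1ccoc1` has not yet been measured. It differs from compound 1 by a single change: (phenoxymethyl)carbonyl in place of hydrogen on an oxygen on a saturated carbon. Here (phenoxymethyl)carbonyl stands in place of hydrogen on an oxygen on a saturated carbon.

Going by the values given here, no measured step shows this change directly, so the expectation is loose. In this assay a modest move to a lower number is expected, smaller than the gap down to compound 3 at 22900 nM, and possibly not beyond the scatter. The expected step runs a 2.0-fold lower number from compound 1 to compound 4 (0.30 log units; within the scatter). For compound 4 the estimate is 40000 nM, with an expected range of 14000 nM to 100000 nM.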

Compound 4, half-maximal inhibitory concentration: 36800 nM
Estimate against measurement, compound 4: 1.1-fold (0.04 log units) above, within the range that was stated.
By their numbers in this assay, from the lowest: compounds 3 and 4 (each within the scatter of the next); then compound 1. At a limit, above all of these: compound 2.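

In this assay, going by these compounds alone, the replacement of hydrogen by (phenoxymethyl)carbonyl on an oxygen on a saturated carbon gives a 2.2-fold lower number from compound 1 to compound 4 (0.33 log units; beyond the scatter) and is the first change here that can be read at a single place. Compounds 2 and 3 each differ from compound 1 in two places, so neither could show what one ester at this oxygen does alone, while compound 4 shows that this ester, aromatic ring included, is compatible with a modest gain while the other hydroxy stays free. No measurement shown gives a reason for this step.

As far as these compounds go, it remains open whether the phenoxy ring matters or the ester alone would do, as a plain acetyl or a longer chain on this oxygen would tell. Also open, from the compounds shown here alone, is how an amine or a carboxylic acid at the end of the ester would read, and what the same ester would do on the remaining hydroxy.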